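Working notes: compound 3 to compound 4

The source may hold more compounds than are shown below. What is called first, only, known or untested is meant among the compounds shown, and "the series" means these compounds.

Measured so far in an ADME assay on NIH3T3 cells (Mus musculus) for cytotoxicity, with a stated time of 72 h; on this read-out higher numbers stand for weaker inhibition and lower numbers for stronger inhibition:
- compound 1 `OC[C@H]1O[C@@H](n2cnc3c(NCc4cccc(Br)c4)ncnc32)[C@H](O)[C@@H]1O` gives > 166000 nM (a limit)
- compound 2 `Cc1cccc(CNc2ncnc3c2ncn3[C@@H]2O[C@H](CO)[C@@H](O)[C@H]2O)c1` gives > 166000 nM (a limit)
- compound 3 `COc1cccc(CNc2ncnc3c2ncn3[C@@H]2O[C@H](CO)[C@@H](O)[C@H]2O)c1OC` gives "not determined" (no result reported)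

Compound 3 has no number to stand on, and the two other values in the series are limits only. Compound 4 `OC[C@H]1O[C@@H](n2cnc3c(NCc4ccc(F)cc4Cl)ncnc32)[C@H](O)[C@@H]1O` carries 2-chloro-4-fluorophenyl in place of 2,3-dimethoxyphenyl on a saturated chain carbon bound to a nitrogen on an aromatic ring.

Going by the values given here, the one measured step (a step that the two limits leave unreadable from compound 1 to compound 2) has no readable size, so no step size carries over to this change. What bears on it is the shared ceiling of the series (the limit of > 166000 nM in this assay, at which 2 of the 3 values shown sit). No step beyond the scatter is expected in this assay, and no direction, since compound 2 keeps the limit (> 166000 nM) shared with compound 1. Compound 4 is estimated at 166000 nM (expected range 70000 nM to 250000 nM), and a report as a limit only is the likely outcome.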

Compound 4, half-maximal inhibitory concentration: > 166000 nM
Compound 4: a limit, no number (the forecaster's own chance of this, stated with the estimate: 80%); the middle value sits exactly at the limit.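

In this assay, going by these compounds alone, compound 4 gives > 166000 nM as a limit and not a number, so no step from compound 1 or compound 2 to compound 4 can be read. The compounds shown leave open how strong any inhibition is, with the series held at one ceiling: the limit of > 166000 nM in this assay, at which 3 of the 4 values shown sit.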